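This account rests on a few compounds, and the source may have more. Where it says the series, first, only, none or still open, it means among the compounds named here.

Compounds measured so far, with their values:
- compound 1, `COc1ccc(/C=C/C=C/C(=O)c2cc(Cl)ccc2O)cc1`: "not active" (no number reported)
- compound 2, `COc1ccc(/C=C/C=C/C(=O)c2ccccc2O)cc1`: 40%
- compound 3, `O=C(/C=C(O)/C=C/c1ccc(Cl)cc1)c1cc(Cl)ccc1O`: "not active" (no number reported)

In an in vitro assay on cells for inhibition of Amine oxidase [flavin-containing] A (Homo sapiens), read by Amplex Red, with a stated time of 15 min, tested at 100 uM (on this read-out higher numbers stand for more inhibition at the one concentration tested (going by the name of the read-out) and lower numbers for less inhibition), compound 3 is reported as "not active" (no number reported), and no single number was given for it; compound 1 stands in the same position, also without a number. Compound 2, in contrast, gives 40% in this assay. The next compound, compound 4, `O=C(/C=C(O)/C=C/c1ccc(Cl)cc1)c1ccccc1O`, has not been measured in this assay. It differs from compound 3 by hydrogen in place of chloro on an aromatic carbon. The same kind of change separates compound 1 from compound 2, and there the values show that compound 1 gave no number while compound 2 gave 40%. For the measured compounds named here, on that basis the step from compound 3 to compound 4 in this assay is expected to go toward more inhibition, and possibly beyond the usual scatter, though with only one comparable pair this is uncertain. Compound 4 is therefore expected to give about 30% in this assay, with a range from 0% to 60%.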

Compound 4, a percentage reported as inhibition, at one concentration (the size of the read-out at that concentration, not a potency): "not active" (no number reported)
Compound 4: no number reported, and the estimate cannot be compared.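

Like compound 3, compound 4 is reported as "not active" (no number reported) in this assay, so no step between compound 3 and compound 4 can be read. Nothing shown here accounts for this result. The compounds shown leave open whether exchanging chloro for hydrogen changes inhibition in this pair.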